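Naphthyl in Place of Methoxyphenyl: Expected Growth Inhibition

This account rests on a few compounds, and the source may have more. Where it says the series, first, only, none or still open, it means among the compounds named here.

Among the measured compounds shown here, compound 3 `COc1ccc(C2=NN(C3=NC(=O)/C(=C4\C(=O)Nc5ccc(Br)cc54)S3)C(c3ccc(OC)cc3)C2)cc1` sits second highest of the three numbers so far in a functional assay on cells (Cancer cell lines, Homo sapiens) for cytotoxicity, read by sulforhodamine B assay, with a stated time of 48 h (on this read-out higher numbers stand for weaker inhibition of growth and lower numbers for stronger inhibition of growth), giving 32500 nM. Compound 2 `COc1ccc(C2=NN(C3=NC(=O)/C(=C4\C(=O)Nc5ccccc54)S3)C(c3ccc(OC)cc3)C2)cc1` gives 100000 nM, and compound 1 `COc1ccc(C2CC(c3ccccc3)=NN2C2=NC(=O)/C(=C3\C(=O)Nc4ccc(Br)cc43)S2)cc1` gives 3630 nM. The step of a 3.1-fold lower number from compound 2 to compound 3 (0.49 log units; beyond the scatter) came with bromo in place of hydrogen on an aromatic carbon, while a 9.0-fold higher number from compound 1 to compound 3 (0.95 log units; beyond the scatter) came with methoxy in place of hydrogen on an aromatic carbon. Compound 4 `COc1ccc(C2CC(c3ccc4ccccc4c3)=NN2C2=NC(=O)/C(=C3\C(=O)Nc4ccc(Br)cc43)S2)cc1` differs from compound 3 by naphthalen-2-yl in place of 4-methoxyphenyl on a carbon with a double bond to nitrogen. For the measured compounds named here, the only measured step that bears on this is the one from compound 1, which also removed a methoxy group and gave the modest worsening a 9.0-fold higher number from compound 1 to compound 3 (0.95 log units; beyond the scatter); its reverse suggests a lower number of similar size. Compound 4 is therefore expected to give 5000 nM, ranging from 1500 nM to 20000 nM, which would mean a 6.5-fold lower number from compound 3 to compound 4 (0.81 log units; beyond the scatter).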

Compound 4, concentration for total growth inhibition: 850 nM
Estimate against measurement, compound 4: 5.9-fold (0.77 log units) above; the whole stated range lies above it.
By their numbers in this assay, from the lowest: compound 4; then compound 1; then compound 3; then compound 2.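

In this assay, among the compounds shown here, this position, a carbon with a double bond to nitrogen, proves more sensitive than the earlier compounds showed: a 38-fold lower number from compound 3 to compound 4 (1.58 log units; beyond the scatter) came with naphthalen-2-yl in place of 4-methoxyphenyl. The second aromatic ring also improves on phenyl, as a 4.3-fold lower number from compound 1 to compound 4 (0.63 log units; beyond the scatter) came with naphthalen-2-yl in place of phenyl. No measurement given here explains this order. Still open, from the compounds shown here alone, is whether naphthalen-2-yl would give the same gain without the bromo group on the core. Also open, going by these compounds, is whether a cyclohexyl group or an amine at this position would match it.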